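A few compounds are considered here, and "the series" means these few. Any claim that something is new, unique, unknown or untested is made for them only; others in the source may bear on it.

Compound 1 `Cc1csc(-c2cncc(Cl)c2N2CCC3(CCNC3=O)CC2)c1` was tested in a functional assay on MV4-11 cells (Homo sapiens) for inhibition, read by resazurin assay, with a stated time of 72 h (on this read-out lower numbers stand for stronger inhibition of growth and higher numbers for weaker inhibition of growth), where compound 1 gives 650 nM. Going by the values given here, that is the lowest of the three numbers measured so far. Compound 2 `O=C1NCCC12CCN(c1c(Cl)cncc1-c1ccc(CN3CCCC3)s1)CC2` gives 3370 nM in this assay, and compound 3 `CC(C)(C)OC(=O)N1CCN(Cc2ccc(-c3cncc(Cl)c3N3CCC4(CCNC4=O)CC3)s2)CC1` gives 5150 nM; both of those numbers lie well above the number of compound 1, by more than the usual scatter, so compound 1 is the strongest growth inhibitor among the three measured compounds.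

Compound 4 `O=Cc1cc(-c2cncc(Cl)c2N2CCC3(CCNC3=O)CC2)cs1` has not been measured yet. It keeps the shared core of compound 1 and changes only the group attached to one aromatic carbon: 5-formylthiophen-3-yl in place of 4-methylthiophen-2-yl on an aromatic carbon. Among the compounds with values here, no pair of measured compounds differs in exactly one place, so there is no measured step to lean on directly. What the numbers do show is that the other two thiophene-carrying compounds, compound 2 and compound 3, sit far above compound 1 in this assay. On that basis a moderate weakening is expected from compound 1 to compound 4, a step of a 1.7-fold higher number from compound 1 to compound 4 (0.23 log units; within the scatter), though a result within the scatter would not be surprising. For compound 4 the estimated value in this assay is 1100 nM, with a range from 400 nM to 3200 nM.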

Compound 4, concentration for 50% growth inhibition: 730 nM
Beside the measured number, compound 4's estimate is 1.5-fold (0.18 log units) above it; low and high end bracket the measured number.
By their numbers in this assay, from the lowest: compounds 1 and 4 (each within the scatter of the next); then compounds 2 and 3 (each within the scatter of the next).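

In this assay, going by these compounds alone, placing 5-formylthiophen-3-yl instead of 4-methylthiophen-2-yl on the aromatic carbon of the shared core gives a 1.1-fold higher number from compound 1 to compound 4 (0.05 log units; within the scatter), the first comparison here between two compounds that differ in only one place. This position therefore accepts this replacement with no readable change in growth inhibition, even though the thiophene is attached through a different ring carbon and carries a formyl group in place of the methyl group. Both of those features change in this one step, so it cannot show what either contributes alone, and nothing in the available data explains why the two compounds read alike.

The compounds shown leave open whether a carboxylic acid or a primary amine in place of the formyl group on this thiophene would keep the number in the same range. They also leave open whether this position would tolerate a phenyl ring in place of the thiophene, or a thiophene carrying no added group at all.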